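The source may report more compounds than this note shows. Statements on the series, on what has been measured and on what is new or still open speak of the compounds shown alone.

Measured compounds:
compound 1 `CC(C)Cn1c(N)nc2c1c(=O)n(CC1CC1)c(=O)n2CC1CC1`: 12%
compound 2 `Nc1nc2c(c(=O)n(CC3CC3)c(=O)n2CC2CC2)n1S(=O)(=O)c1ccc(C(F)(F)F)cc1`: 0%
compound 3 `Nc1nc2c(c(=O)n(CC3CC3)c(=O)n2CC2CC2)n1S(=O)(=O)c1ccc(Cl)cc1`: 1%

In an assay on isolated protein with dual specificity calcium/calmodulin-dependent 3',5'-cyclic nucleotide phosphodiesterase 1B (Bos taurus) as the target, tested at 100 uM (a higher number here means more inhibition at the concentration tested (going by the name of the read-out), a lower number less inhibition), compound 3 stands second highest of the three numbers. Its nearest neighbour is compound 2, a number 1 percentage points higher from compound 2 to compound 3 (within the scatter); the furthest is compound 1, a number 11 percentage points lower from compound 1 to compound 3 (beyond the scatter), where an isobutyl sat on the aromatic nitrogen instead of an arylsulfonyl group.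

Compound 4 `COc1ccc(OC)c(S(=O)(=O)n2c(N)nc3c2c(=O)n(CC2CC2)c(=O)n3CC2CC2)c1` keeps the arylsulfonyl group on that nitrogen and changes only the ring attached to the sulfonyl sulfur: 2,5-dimethoxyphenyl in place of 4-chlorophenyl on a sulfonyl sulfur. For the measured compounds named here, the one measured step that bears on this, the swap of the substituent on that aryl ring from compound 2 to compound 3, stayed within the scatter. Going by the values given here, no other step touches this ring. A step within the scatter is therefore expected, a number 2 percentage points higher from compound 3 to compound 4 (within the scatter). Compound 4 is estimated at 3%, with a range from 0% to 12%.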

Compound 4, a percentage reported as inhibition, at one concentration (the size of the read-out at that concentration, not a potency): 31%
Beside the measured number, compound 4's estimate is 28 percentage points below it; the measured number lies above the stated range.
By their numbers in this assay, from the lowest: compounds 2 and 3 (each within the scatter of the next); then compound 1; then compound 4.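

The ring on the sulfonyl sulfur can clearly change this read-out: 2,5-dimethoxyphenyl in place of 4-chlorophenyl gives a number 30 percentage points higher from compound 3 to compound 4 (beyond the scatter) and in place of 4-(trifluoromethyl)phenyl gives a number 31 percentage points higher from compound 2 to compound 4 (beyond the scatter) even though swapping chloro for trifluoromethyl had stayed within the scatter. Nothing available explains this gain.

As far as these compounds go, both methoxy groups enter together, so it remains open whether one alone would be enough. Also open, from the compounds shown here alone, is how a plain phenyl, or a ring carrying a hydroxyl or an amine, would compare.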